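Replacing a Nitrile with a Tolyl Group: Expected Efficacy

The source may hold more compounds than are shown below. What is called first, only, known or untested is meant among the compounds shown, and "the series" means these compounds.

In a functional assay on 1321-N1 cells for agonist activity at Free fatty acid receptor 1 (Homo sapiens), read by calcium flux (on this read-out lower numbers stand for smaller maximal responses and higher numbers for larger maximal responses), compound 1 `O=C(O)CCc1ccc(COc2ccccc2)cc1` gives 88%. Compound 2 `N#Cc1cccc(COc2ccc(CCC(=O)O)cc2)c1` reaches, in this assay, 102%. Of the two numbers in hand, compound 2 stands highest, and its gap to compound 1, the nearest value, lies beyond the usual scatter of repeated runs, so compound 2 is the fuller agonist of the pair in this setting.

Compound 3 `Cc1ccc(-c2cccc(COc3ccc(CCC(=O)O)cc3)c2)cc1` has not yet been measured in this assay. It departs from compound 2 in a single place: 4-methylphenyl in place of cyano on an aromatic carbon. Among the measured compounds shown here, no pair of measured compounds shows a change of this kind, so nothing in the data tells how the read-out responds to it; the two values only show that both measured compounds are close to full agonists.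

Given that compound 2 already sits at the top of the range with 102%, a step of roughly the size a number 7 percentage points lower from compound 2 to compound 3 (within the scatter) is expected, downward but probably not much beyond the scatter. For compound 3 in this assay an efficacy of 95% is estimated, with a plausible range from 72% to 112%.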

Compound 3, largest response reached (reported as efficacy), in percent of the reference or control that the assay uses: 86%
For compound 3 the middle estimate is 9 percentage points above the measured one; low and high end bracket the measured number.
By their numbers in this assay, from the lowest: compounds 3 and 1 (each within the scatter of the next); then compound 2.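

In this assay, 4-methylphenyl in place of cyano on this aromatic carbon gives a number 16 percentage points lower from compound 2 to compound 3 (beyond the scatter), the only step shown for a change at this position, and it is a modest one. The position therefore tolerates a swap from a nitrile of 2 heavy atoms to a six-membered aromatic ring bearing a methyl group, 7 heavy atoms in all, with compound 3 still reaching 86%, although the maximal response does not stay at the level of compound 2. Nothing available accounts for this drop in response.

The compounds shown leave open whether the lower response follows from losing the nitrile or from introducing the new ring, and whether the methyl group on that ring plays any part, a question that an unsubstituted phenyl, a 4-methoxyphenyl or a 4-chlorophenyl at the same carbon would address. They also leave open whether a small group such as a single methyl or a chlorine on this carbon would hold the response of compound 2 or fall to that of compound 3.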